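Removing a chloro group from the strongest compound in a small series

The source may hold more compounds than are shown below. What is called first, only, known or untested is meant among the compounds shown, and "the series" means these compounds.

Of the compounds shown here, three sharing one core have been tested in a functional assay on U-87MG ATCC cells for antiproliferative activity against U-87 MG (Homo sapiens), read by MTT assay, with a stated time of 48 h, tested at 100 uM; a higher number here means a weaker effect of the compound at the concentration tested, a lower number a stronger effect. Compound 1 `COc1ccc(-c2nc(C)c(C(=O)CSc3nc(-c4ccc(Cl)cc4)c(C#N)c(=O)[nH]3)s2)cc1` gives 2.85% and has the lowest number of the three. Compound 2 `Cc1nc(-c2ccccc2)sc1C(=O)CSc1nc(-c2ccc(Cl)cc2)c(C#N)c(=O)[nH]1` gives 22.5%, and compound 3 `Cc1nc(-c2ccc(Cl)cc2)sc1C(=O)CSc1nc(-c2ccc(Cl)cc2)c(C#N)c(=O)[nH]1` gives 12.8%. The step of a number 19.7 percentage points higher from compound 1 to compound 2 (beyond the scatter) is the only one beyond the scatter; the steps of a number 10 percentage points higher from compound 1 to compound 3 (within the scatter) and a number 9.7 percentage points lower from compound 2 to compound 3 (within the scatter) both lie within it.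

Compound 4 `COc1ccc(-c2nc(C)c(C(=O)CSc3nc(-c4ccccc4)c(C#N)c(=O)[nH]3)s2)cc1` is not yet measured. It differs from compound 1 by hydrogen in place of chloro on an aromatic carbon. Among the compounds with values here, none of the measured steps changes this same group; the nearest comparison is the change of chloro against hydrogen seen in the step of a number 9.7 percentage points lower from compound 2 to compound 3 (within the scatter), which stayed within the scatter, whereas the larger step of a number 19.7 percentage points higher from compound 1 to compound 2 (beyond the scatter) concerns the methoxy group rather than a chloro group. The bearing of these steps on compound 4 is therefore loose.

Compound 1 sits so low that any change is more likely to raise than to lower its number. Compound 4 is therefore expected to show a small rise, a number 7.2 percentage points higher from compound 1 to compound 4 (within the scatter), probably within the scatter. The estimate for compound 4 in this assay is 10%, with a range from 2% to 30%.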

Compound 4, a percentage reported as activity, at one concentration (the size of the read-out at that concentration, not a potency): 10.9%
Compound 4: the middle estimate sits 0.9 percentage points below what was measured; measured number inside the range.
By their numbers in this assay, from the lowest: compounds 1, 4, 3 and 2 (each within the scatter of the next, the first and the last beyond it).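

Compound 4 is the only compound shown in which the 4-chlorophenyl group on the core of compound 1 is changed, since compounds 1, 2 and 3 all carry it, and in this assay the exchange for phenyl is a small step: a number 8.1 percentage points higher from compound 1 to compound 4 (within the scatter). A chloro group at this place, para to a large group, therefore does not appear to be required for a low number in this assay, at least on the core that carries the methoxy group. The change also reads much the same on the two cores on which it can be followed, and neither step leaves the scatter, so the series gives no sign so far that the effect of this change depends on the core: the same change on two cores in this assay, a number 9.7 percentage points lower (within the scatter) from compound 2 to compound 3 and a number 8.1 percentage points lower (within the scatter) from compound 4 to compound 1, 1.7 percentage points apart, within the scatter of two such steps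

Going by these compounds, whether a larger or differently built group at this place, such as an amine, a carboxylic acid or a longer chain, would move the number beyond the scatter remains open. Also open, on these data alone, is whether compound 1 and compound 4 differ in potency, a question that a read-out at one concentration cannot settle.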